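A few compounds are considered here, and "the series" means these few. Any claim that something is new, unique, unknown or untested is made for them only; others in the source may bear on it.

Measured compounds: compound 1, `CCCCNc1nc(N)nc2cc(C(N)=O)ccc12`, with > 18000 nM; compound 2, `CCCCNc1nc(N)nc2cccc(Cl)c12`, with 100 nM.

Of the compounds shown here, two sharing one core have been tested in an ADME assay on HEK293 cells (Homo sapiens) for cytotoxicity, with a stated time of 6 h; on this read-out lower numbers stand for higher toxicity in this test and higher numbers for lower toxicity in this test. For compound 1 the result > 18000 nM is a limit of the assay rather than a number, and it is the limit of > 18000 nM in this assay, at which 1 of the 2 values shown sits. Within the data shown here, compound 2 gives 100 nM in this assay, which is the only outright number among the two results. Compound 3, `CCCCNc1nc(N)nc2cccc(CC3CCCC3)c12`, has not yet been measured. It differs from compound 2 in one place: cyclopentylmethyl in place of chloro on an aromatic carbon. Among the measured compounds shown here, no step between measured compounds bears on such an exchange, so the expectation rests on compound 2 alone. The expected change is a 1.5-fold higher number from compound 2 to compound 3 (0.18 log units; within the scatter), and it is expected to stay within the usual scatter rather than to move clearly in either direction. Compound 3 is therefore estimated at 150 nM in this assay, within a range from 30 nM to 1500 nM.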

Compound 3, half-maximal cytotoxic concentration: > 25000 nM
Compound 3: only a limit was reported; the forecaster's own chance of this, stated with the estimate: 10%; middle value at least 160-fold (2.22 log units) away from the limit.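

Among these compounds, at this place on an aromatic carbon, cyclopentylmethyl in place of chloro is the first single exchange that can be read in this assay, and it gives an at least 250-fold higher number from compound 2 to compound 3 (2.39 log units; beyond the scatter). Going by these compounds, the true size of that step stays unknown, as the result for compound 3 is a limit of the assay and not a number: the limit of > 25000 nM in this assay, at which 1 of the 3 values shown sits. The step shows that a change in this one place is enough to take the shared core from an outright number to a limit, which compound 1 and compound 2 could not show, as they differ in more than one place.

The compounds shown do not separate the loss of chloro from the arrival of cyclopentylmethyl, and they give no cause for the step. On these data alone, how a methyl, a methoxy or a primary amine in the same place would read in this assay also remains open.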